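A few compounds are considered here, and "the series" means these few. Any claim that something is new, unique, unknown or untested is made for them only; others in the source may bear on it.

Of the compounds shown here, two built on the same core have been measured. Compound 1 `Cc1cc(C(=O)N2CCCCc3ccccc32)ccc1CNC(=O)NCC(N)=O` carries a (carbamoylmethyl)amino group on a carbonyl carbon, and in a functional assay on HEK293 cells for agonist activity at Vasopressin V2 receptor (Homo sapiens), read by a luciferase reporter and cAMP accumulation (on this read-out lower numbers stand for an effect already at smaller amounts and higher numbers for an effect only at larger amounts of compound), compound 1 gives 210 nM. Compound 2 `Cc1cc(C(=O)N2CCCCc3ccccc32)ccc1CNC(=O)N1CCC[C@H]1C(=O)O` carries a 2-carboxypyrrolidin-1-yl group there instead, and in this assay compound 2 gives 680 nM. Among the compounds with values here, that exchange produced a 3.2-fold higher number from compound 1 to compound 2 (0.51 log units; beyond the scatter), so compound 2 stands with the highest of the two numbers, with compound 1 as its only neighbour.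

Compound 3 `Cc1cc(C(=O)N2CCCCc3ccccc32)ccc1CNC(=O)N1CCC[C@H]1C(=S)N(C)C` keeps the five-membered ring of compound 2 but changes the group on its saturated ring carbon: a group of 5 heavy atoms (3 carbon, 1 nitrogen, 1 sulfur; no ring) in place of a group of 3 heavy atoms (1 carbon, 2 oxygen; no ring), on a saturated ring carbon. Within the data shown here, no measured step removes a carboxy group or brings in a group of this kind, so the one step on record, from compound 1 to compound 2, concerns the same carbonyl carbon but not the same exchange. It shows that a change at this point moved the number by a modest amount rather than a large one. On that basis compound 3 is expected to land near its neighbours, with an estimated value of 400 nM in this assay, between 120 nM and 1300 nM, which corresponds to an expected step of a 1.7-fold lower number from compound 2 to compound 3 (0.23 log units; within the scatter).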

Compound 3, half-maximal effective concentration: 3.2 nM
Beside the measured number, compound 3's estimate is 130-fold (2.10 log units) above it; the measured number lies below the stated range.
By their numbers in this assay, from the lowest: compound 3; then compound 1; then compound 2.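

Within the data shown here, on the saturated ring carbon next to the ring nitrogen, the exchange of carboxy for the group of 5 heavy atoms (3 carbon, 1 nitrogen, 1 sulfur) gives a 210-fold lower number from compound 2 to compound 3 (2.33 log units; beyond the scatter) in this assay, which shows that this one position can move the number far more than the only earlier step suggested. The five-membered ring is also no barrier to a low number, since the step on the carbonyl carbon gives a 66-fold lower number from compound 1 to compound 3 (1.82 log units; beyond the scatter) and so the ring-bearing group of compound 3 surpasses the open-chain group of compound 1 in this read-out. The group that leaves and the group that enters differ at once in their heavy atoms and in hydrogen-bond donors, 1 against 0, while each has 1 hydrogen-bond acceptor and no net charge, so several differences travel together in this single exchange.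

No measurement shown here explains why the number dropped so far. Still open, going by these compounds, is how much of the drop belongs to the sulfur and how much to the two methyl groups on nitrogen, a question that a group with oxygen in place of that sulfur, or a methyl ester on the same ring carbon, would bear on.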